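The compounds below may be only part of what the source reports. "The series", "measured", "known", "first", "only" and "open" are said of these compounds alone.

Measured compounds:
Compound 1, `COc1cc(-c2cc(/C=C/C(=O)c3ccc(N)cc3)[nH]n2)cc(OC)c1OC`, in a functional assay on U-251 cells (Homo sapiens) for cytotoxicity, read by sulforhodamine B assay, with a stated time of 48 h, tested at 0.01 uM; a higher number here means a weaker effect of the compound at the concentration tested, a lower number a stronger effect: 98%
Compound 2, `COc1ccc(C(=O)/C=C/c2cc(-c3cc(OC)c(OC)c(OC)c3)n[nH]2)cc1OC`, in this assay: 96%
Compound 3, `COc1ccc(C(=O)/C=C/c2cc(-c3cc(OC)c(OC)c(OC)c3)n[nH]2)cc1`, in this assay: 97%

All three share a core and differ only in the aryl group on the carbonyl carbon. Their numbers lie close together: the step from compound 1 to compound 3 is a number 1 percentage points lower from compound 1 to compound 3 (within the scatter), and the step from compound 2 to compound 3 is a number 1 percentage points higher from compound 2 to compound 3 (within the scatter), so compound 3 cannot be separated from either neighbour by these readings.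

Compound 4, `COc1cc(-c2cc(/C=C/C(=O)c3ccc(F)c(F)c3)[nH]n2)cc(OC)c1OC`, is the next compound in this series. Its change from compound 3 is 3,4-difluorophenyl in place of 4-methoxyphenyl on a carbonyl carbon. Among the measured compounds shown here, the steps that bear on this are the earlier changes at the same place, a number 2 percentage points lower from compound 1 to compound 2 (within the scatter) and a number 1 percentage points higher from compound 2 to compound 3 (within the scatter), both within the scatter. The expected step in this assay is therefore no change at the digits printed from compound 3 to compound 4 (within the scatter), that is none beyond the scatter. Compound 4 is thus estimated at 97%, with a range from 88% to 104%.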

Compound 4, a percentage reported as activity, at one concentration (the size of the read-out at that concentration, not a potency): 97%
Estimate against measurement, compound 4: no gap at the digits printed; measured number inside the range.
By their numbers in this assay, from the lowest: compounds 2, 3, 4 and 1 (each within the scatter of the next).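

In this assay, putting 3,4-difluorophenyl in place of 4-methoxyphenyl on the carbonyl carbon gives no change at the digits printed from compound 3 to compound 4 (within the scatter), and the comparisons with the other two aryl groups give a number 1 percentage points higher from compound 2 to compound 4 (within the scatter) and a number 1 percentage points lower from compound 1 to compound 4 (within the scatter). Among the compounds shown here, this is the first fluorine-bearing aryl group at this position, and it has no hydrogen-bond acceptor where 4-methoxyphenyl has one, yet this change in the group leaves the reading within the scatter of all three earlier compounds. Nothing available explains why these readings stay together.

Still open, from the compounds shown here alone, is whether any group on the carbonyl carbon can move this reading beyond the scatter, such as a phenyl ring carrying a carboxylic acid, or a cyclohexyl ring. The single concentration also leaves open whether these four compounds would separate at a higher concentration.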